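Thiazolyl in place of phenyl on the amide carbonyl

The compounds below may be only part of what the source reports. "The series", "measured", "known", "first", "only" and "open" are said of these compounds alone.

Measured in a functional assay on HEK293 cells for positive allosteric modulation of metabotropic glutamate receptor 5 (Homo sapiens), read by calcium flux; on this read-out higher numbers stand for larger maximal responses and lower numbers for smaller maximal responses:
Compound 1, `O=C(c1ccccc1)N1CCCn2nc(COc3ccccc3)cc21`: 63%
Compound 2, `O=C(c1cccc(F)c1)N1CCCn2nc(COc3ccccc3)cc21`: 61%
Compound 3, `O=C(c1ccno1)N1CCCn2nc(COc3ccccc3)cc21`: 22%

Compound 1 stands highest of the three numbers, though compound 2 lies within the scatter of it, a number 2 percentage points lower from compound 1 to compound 2 (within the scatter). Compound 3 sits far lower, a number 41 percentage points lower from compound 1 to compound 3 (beyond the scatter), and the same is seen in a number 39 percentage points lower from compound 2 to compound 3 (beyond the scatter). Compound 4, `O=C(c1nccs1)N1CCCn2nc(COc3ccccc3)cc21`, differs from compound 1 by 1,3-thiazol-2-yl in place of phenyl on a carbonyl carbon. The steps from compound 1 and compound 2 to compound 3 both replace the aromatic six-membered ring on the carbonyl with a five-membered heteroaromatic ring, and both were large and downward. The change to compound 4 is of the same kind, so a downward step beyond the scatter is expected, a number 28 percentage points lower from compound 1 to compound 4 (beyond the scatter). Compound 4 is therefore estimated at 35%, within 15% to 58%.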

Compound 4, largest response reached (reported as percent of maximum), in percent of the reference or control that the assay uses: 24%
The estimate for compound 4 lay 11 percentage points above the measured number, within the range that was stated.
By their numbers in this assay, from the lowest: compounds 3 and 4 (each within the scatter of the next); then compounds 2 and 1 (each within the scatter of the next).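

In this assay, a second five-membered heteroaromatic ring on the carbonyl carbon also falls well short of phenyl (a number 39 percentage points lower from compound 1 to compound 4 (beyond the scatter)) and of 3-fluorophenyl (a number 37 percentage points lower from compound 2 to compound 4 (beyond the scatter)). Between the two five-membered rings, the exchange of 1,2-oxazol-5-yl for 1,3-thiazol-2-yl makes little difference (a number 2 percentage points higher from compound 3 to compound 4 (within the scatter)), so the loss is not confined to the 1,2-oxazol-5-yl group of compound 3. Nothing available gives a reason for this loss. The compounds shown leave open whether a pyridyl or a cyclohexyl group on the carbonyl carbon would keep the response of compound 1.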